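Swapping diethylamino for pyrrolidinyl on two related cores

The compounds below may be only part of what the source reports. "The series", "measured", "known", "first", "only" and "open" are said of these compounds alone.

Of the compounds shown here, three have been measured in an ADME assay on L6 cells (Rattus norvegicus) for cytotoxicity, read by fluorescence, with a stated time of 72 h; on this read-out higher numbers stand for weaker inhibition and lower numbers for stronger inhibition. Compound 1 `CN1CCN(C23CC(NC(=O)CN4CCCC4)C(C(c4ccccc4)C2)C(c2ccccc2)C3)CC1` gives 27800 nM. Compound 2 `CCN(CC)CC(=O)NC1CC2(N3CCN(C)CC3)CC(c3ccccc3)C1C(c1ccccc1)C2` gives 26400 nM in this assay. Compound 3 `CCN(CC)CCCN1CCC2(N3CCN(C)CC3)CC(c3ccccc3)C1C(c1ccccc1)C2` gives 68100 nM in this assay, the highest of the three. The difference between the cores of compound 2 and compound 3 is not broken down here. Compound 1 differs from compound 2 by pyrrolidin-1-yl in place of diethylamino on a saturated chain carbon bound to a carbonyl carbon, and this gave a 1.1-fold higher number from compound 2 to compound 1 (0.02 log units; within the scatter). Compound 4 `CN1CCN(C23CCN(CCCN4CCCC4)C(C(c4ccccc4)C2)C(c2ccccc2)C3)CC1`, not yet measured, differs from compound 3 by pyrrolidin-1-yl in place of diethylamino on a saturated chain carbon, three bonds along the chain from an amine nitrogen in a ring. This is the same kind of change, but around a different place: in one case the saturated chain carbon is bound to a carbonyl carbon, in the other it is three bonds along the chain from an amine nitrogen in a ring. Because the earlier step was a 1.1-fold higher number from compound 2 to compound 1 (0.02 log units; within the scatter), a similarly small step is expected, namely a 1.1-fold higher number from compound 3 to compound 4 (0.02 log units; within the scatter). Compound 4 is therefore estimated at 72000 nM, with compound 4 likely falling between 36000 nM and 145000 nM.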

Compound 4, half-maximal inhibitory concentration: 43500 nM
Compound 4: middle estimate off by 1.7-fold (0.22 log units), on the high side; measured number inside the range.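

In this assay, putting pyrrolidin-1-yl in place of diethylamino on the chain gave a 1.6-fold lower number from compound 3 to compound 4 (0.19 log units; within the scatter), so this step is too small to count as a real change. Set beside the earlier step, the swap reads the same on both cores, with no difference that can be told from scatter: the same change on two cores in this assay, a 1.1-fold higher number (0.02 log units; within the scatter) from compound 2 to compound 1 and a 1.6-fold lower number (0.19 log units; within the scatter) from compound 3 to compound 4, 1.6-fold (0.22 log units) apart, within the scatter of two such steps. Going by these compounds alone, this shows only that the swap left this read-out within the scatter on these two cores; two pairs cannot show that the same would hold on any other core or in any other assay.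

The compounds shown leave open how other amines on the same chain, such as dimethylamino, piperidin-1-yl or morpholin-4-yl, would read here.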